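Replacing a cyclohexyl ring with piperidin-4-yl on the amide

The compounds below may be only part of what the source reports. "The series", "measured", "known", "first", "only" and "open" are said of these compounds alone.

Compound 2 `CN(Cc1cc(C(F)(F)F)cc(C(F)(F)F)c1)C(=O)[C@H]1CN(C(=O)C2CCCCC2)C[C@@H]1c1ccccc1` gives 0.68 nM in an assay on CHO cells for displacement of a labelled ligand from Substance-P receptor (Homo sapiens); a higher number here means a weaker inhibitor, a lower number a stronger inhibitor. Going by the values given here, that is the lower of the two numbers measured so far, but its only neighbour, compound 1 `CN(Cc1cc(C(F)(F)F)cc(C(F)(F)F)c1)C(=O)[C@H]1CN(C(=O)c2cnccn2)C[C@@H]1c1ccccc1`, which gives 0.74 nM in this assay, sits so close that the two are within the scatter. Among the compounds with values here, the step of a 1.1-fold lower number from compound 1 to compound 2 (0.04 log units; within the scatter), which puts cyclohexyl in place of pyrazin-2-yl on a carbonyl carbon, is the only measured change at that position, and it left the number essentially unchanged.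

Compound 3 `CN(Cc1cc(C(F)(F)F)cc(C(F)(F)F)c1)C(=O)[C@H]1CN(C(=O)C2CCNCC2)C[C@@H]1c1ccccc1` differs from compound 2 by piperidin-4-yl in place of cyclohexyl on a carbonyl carbon. The ring that enters carries one hydrogen-bond donor and one hydrogen-bond acceptor, where the ring that leaves has none. Within the data shown here, only one measured step touches this position, and because a 1.1-fold lower number from compound 1 to compound 2 (0.04 log units; within the scatter) lay within the scatter, a flat or slightly weaker result is the most reasonable expectation, while the direction remains uncertain. Compound 3 is estimated to give about 1.5 nM, with a likely range from 0.4 nM to 6 nM in this assay. This estimate means an expected step of a 2.2-fold higher number from compound 2 to compound 3 (0.34 log units; beyond the scatter).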

Compound 3, half-maximal inhibitory concentration: 4.1 nM
Estimate against measurement, compound 3: 2.7-fold (0.44 log units) below; measured number inside the range.
By their numbers in this assay, from the lowest: compounds 2 and 1 (each within the scatter of the next); then compound 3.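

In this assay, the group on this carbonyl carbon turns out to matter after all: exchanging cyclohexyl for piperidin-4-yl, which keeps the six-membered ring and its heavy-atom count but puts a nitrogen in place of one ring carbon, gives a 6.0-fold higher number from compound 2 to compound 3 (0.78 log units; beyond the scatter). Putting piperidin-4-yl in place of pyrazin-2-yl gives a similar result, a 5.5-fold higher number from compound 1 to compound 3 (0.74 log units; beyond the scatter), so compound 3 is the weakest of the three, even though pyrazin-2-yl and cyclohexyl, two quite different rings, sit within the scatter of each other. The loss is modest, and nothing available here explains why this one ring change costs potency.

The compounds shown cannot separate the effect of the ring nitrogen from that of the hydrogen it carries, and a 1-methylpiperidin-4-yl ring, with a methyl group on that nitrogen, or a tetrahydropyran-4-yl ring, with an oxygen in its place, would bear directly on that question. From the compounds shown here alone, it also remains open whether a longer chain ending in an amine would behave like compound 3 or like compound 2.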